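The compounds below may be only part of what the source reports. "The series", "measured", "known", "first", "only" and "open" are said of these compounds alone.

In a functional assay on SUP-B15 cells (Homo sapiens) for antiproliferative activity, with a stated time of 72 h (a higher number here means that more compound is needed for the effect, a lower number that less compound is needed), three compounds have been tested so far, and none of them gave a number. Compound 1, with the structure `COc1ccc(-c2cc(=O)c3c(OC)cc(OC)cc3n2S(=O)(=O)c2ccc(OC)cc2)cc1`, reaches only > 82700 nM in this assay, which is a limit of the assay and not a measured value. Compound 2, `COc1cc(OC)c2c(=O)cc(C(=O)Nc3ccccc3S(C)(=O)=O)[nH]c2c1`, likewise stops at a limit, > 39600 nM in this assay. Compound 3, `COC(=O)c1cc(=O)c2cc(NC(=O)Nc3ccc(F)c(Cl)c3)ccc2[nH]1`, also returns a limit, > 12600 nM in this assay. The three limits differ from one another, as shown by the limit of > 12600 nM in this assay, at which 1 of the 3 values shown sits, the limit of > 39600 nM in this assay, at which 1 of the 3 values shown sits, and (the limit of > 82700 nM in this assay, at which 1 of the 3 values shown sits), and compound 3 stands at one of them with no number of its own.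

Compound 4, `COC(=O)c1cc(=O)c2cc(NC(=O)NCc3ccccc3)ccc2[nH]1`, is the next to be measured in this assay. It differs from compound 3 in one place: benzyl in place of 3-chloro-4-fluorophenyl on an amide-type nitrogen. Within the data shown here, no measured pair shows what this swap does here, so there is nothing to set the size or direction of the step against. The step is expected to be a step that the limit leaves unreadable from compound 3 to compound 4, with no direction beyond the scatter. Compound 4 is estimated at 20000 nM, within a range from 5000 nM to 80000 nM, and it is expected that this assay will again report only a limit rather than a number.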

Compound 4, half-maximal effective concentration: > 19500 nM
Compound 4: only a limit was reported; the forecaster's own chance of this, stated with the estimate: 85%; the middle value is on the limit's open side.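

Compound 3 and compound 4 each return only a limit in this assay, and no step can be read between them. The compounds shown leave open what benzyl in place of 3-chloro-4-fluorophenyl does to the effect, and what concentration any of them would need to reach it.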